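Methyl Para to a Large Group: From Compound 3 to Compound 4

The compounds below may be only part of what the source reports. "The series", "measured", "known", "first", "only" and "open" are said of these compounds alone.

Compound 1, `Cc1cccc(Nc2nc(C)c(C(=O)/C=C/c3ccccc3Cl)s2)c1`: in a functional assay on PC-3 cells (Homo sapiens) for cytotoxicity, read by MTT assay (a higher number here means a weaker inhibitor, a lower number a stronger inhibitor), compound 1 gives 22200 nM.
Compound 2, `Cc1ccc(Nc2nc(C)c(C(=O)/C=C/c3ccc(Cl)cc3)s2)cc1`: in this assay compound 2 gives only a limit, > 25000 nM.
Compound 3, `Cc1nc(Nc2ccccc2)sc1C(=O)/C=C/c1ccccc1Cl`: in this assay compound 3 gives only a limit, > 25000 nM.

Compound 3 therefore stands not at a number but at a limit of this assay. It is not alone there: of the three values shown, two sit at that limit (the limit of > 25000 nM in this assay, at which 2 of the 3 values shown sit), so the measured set gives little room for ranking.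

Compound 4, `Cc1ccc(Nc2nc(C)c(C(=O)/C=C/c3ccccc3Cl)s2)cc1`, differs from compound 3 by methyl in place of hydrogen on an aromatic carbon. Within the data shown here, only one measured step bears on this change, and it runs the other way: an at least 1.1-fold higher number from compound 1 to compound 3 (0.05 log units; that floor lies within the scatter), the removal of a methyl from the same ring, a move that stays within the scatter. Adding a methyl back, now para to a large group, is thus expected to shift the number little, if at all, beyond the scatter of this assay.

The step from compound 3 to compound 4 is accordingly estimated as a step that the limit leaves unreadable from compound 3 to compound 4. For compound 4 the estimate in this assay is 28000 nM, within a range of 12000 nM to 70000 nM, with a real chance that the assay again reports only a limit.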

Compound 4, half-maximal inhibitory concentration: > 25000 nM
Compound 4: no number, only a limit; the forecaster's own chance of this, stated with the estimate: 60%; the middle value does not contradict the limit.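

In this assay, methyl in place of hydrogen, para to a large group, leaves compound 4 with only a limit, as compound 3 has, so the steps to compound 4 from compound 3 and from compound 2 cannot be read. Among these compounds, the one readable step concerns where the methyl sits: 4-methylphenyl in place of 3-methylphenyl on the nitrogen gives an at least 1.1-fold higher number from compound 1 to compound 4 (0.05 log units; that floor lies within the scatter), so this change shows no shift beyond the scatter. The new result also crowds the set further against its ceiling, leaving even less room for ranking: the limit of > 25000 nM in this assay, at which 3 of the 4 values shown sit.

Since compound 1 alone gives a number, the compounds shown leave open whether any change on this ring can move the value in a readable direction, and by how much the compounds at the limit differ from one another. They also do not show what an amine or a carboxylic acid in place of the methyl would do in this assay, nor whether either would bring the value down to a level that can be compared.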